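From 4-methylphenyl to 4-bromophenyl in the series

This account rests on a few compounds, and the source may have more. Where it says the series, first, only, none or still open, it means among the compounds named here.

In a functional assay on HL-60 cells (Homo sapiens) for cytotoxicity, read by MTT assay (a lower number here means a stronger inhibitor, a higher number a weaker inhibitor), compound 1 (`Cc1ccc(S(=O)(=O)NC(C2=CC(=O)c3c(O)ccc(O)c3C2=O)C(C)C)cc1`) stands as "not determined" (no result reported) and offers no number for comparison. In this assay, among the compounds with values here, compound 2 (`CC(=O)c1ccc(S(=O)(=O)NC(C2=CC(=O)c3c(O)ccc(O)c3C2=O)C(C)C)cc1`) gives 110 nM as one of only two numbers so far. Compound 3 (`Cc1ccc(S(=O)(=O)NC(C)C2=CC(=O)c3c(O)ccc(O)c3C2=O)cc1`) gives 30 nM as the lower of those two numbers, and its gap to compound 2 lies beyond the usual scatter. Within the data shown here, no two measured compounds differ in one place only, so the series offers no measured step to carry over.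

Compound 4 (`CC(NS(=O)(=O)c1ccc(Br)cc1)C1=CC(=O)c2c(O)ccc(O)c2C1=O`) is still to be measured. Its structure departs from that of compound 3 in one place: bromo in place of methyl on an aromatic carbon (bromo in place of methyl on an aromatic carbon, para to a large group). Among the measured compounds shown here, with no measured precedent for this change, compound 3 at 30 nM is the only anchor for the expectation. No step beyond the scatter is expected in this assay in either direction. The estimated step of no change at the digits printed from compound 3 to compound 4 (within the scatter) therefore stays within the scatter. For compound 4 the estimated value is 30 nM with an expected range from 10 nM to 90 nM at this stage of the series.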

Compound 4, half-maximal inhibitory concentration: 100 nM
Estimate against measurement, compound 4: 3.3-fold (0.52 log units) below, outside the stated range (above it).
By their numbers in this assay, from the lowest: compound 3; then compounds 4 and 2 (each within the scatter of the next).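

In this assay the series now has its first measured step on this aromatic carbon, para to a large group: the change from 4-methylphenyl to 4-bromophenyl gives a 3.3-fold higher number from compound 3 to compound 4 (0.52 log units; beyond the scatter) and so lies beyond the scatter. The position is therefore not indifferent to a swap of one heavy atom for one heavy atom, even with no ring, hydrogen-bond donor, acceptor or net charge entering or leaving, and in this single pair the methyl of compound 3 carries the lower number. Nothing measured here bears on the origin of the step, so the pair records its size and direction and no explanation.

Open, on these data alone, is whether the step is particular to bromo or would also appear with chloro, fluoro, methoxy, an amine or a carboxylic acid at the same carbon, since one pair sets no trend for this position. Also open, as far as these compounds go, is whether the same change would give a similar step on the side chain of compound 1, where "not determined" (no result reported) stands in place of a number and no comparison can be read.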